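The source may report more compounds than this note shows. Statements on the series, on what has been measured and on what is new or still open speak of the compounds shown alone.

Measured compounds in an ADME assay on the whole organism (plasma) for pharmacokinetics, with Rattus norvegicus as the target, at a dose of 10 mg/kg by the oral route; a lower number here means less compound in the circulation, a higher number more compound in the circulation at the dose given:
compound 1 `CCCCCCOC(=O)/C=C/c1ccc(NC(=O)C2(NC(=O)c3ccc4c(C5CCCC5)c(-c5ncc(Cl)cn5)n(C)c4c3)CCC2)cc1OCC` gives 2320 ng.h/mL
compound 2 `CCOc1cc(NC(=O)C2(NC(=O)c3ccc4c(C5CCCC5)c(-c5ncc(Cl)cn5)n(C)c4c3)CCC2)ccc1/C=C/C(=O)OCCOCCOC` gives 17200 ng.h/mL

Among the compounds with values here, compound 2 holds the higher of the two numbers seen so far in this assay; the one measured step, a 7.4-fold higher number from compound 1 to compound 2 (0.87 log units; beyond the scatter), separates it from compound 1 and lies beyond the scatter.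

Compound 3 `CCOc1cc(NC(=O)C2(NC(=O)c3ccc4c(C5CCCC5)c(-c5ncc(Cl)cn5)n(C)c4c3)CCC2)ccc1/C=C/C(=O)OCC(N)=O` is the next member. It differs from compound 2 by carbamoyl in place of (2-methoxyethoxy)methyl on a saturated chain carbon bound to an oxygen next to a carbonyl group. Within the data shown here, the only step in hand, a 7.4-fold higher number from compound 1 to compound 2 (0.87 log units; beyond the scatter), concerns the same chain end of the ester but exchanges different groups, so it does not fix the outcome of this change; it only shows that this part of the molecule can move the number substantially. Among the measured compounds shown here, no measured step bears directly on the carbamoyl, and the direction is therefore open. Compound 3 is expected to give 8000 ng.h/mL in this assay, with a range of 2500 ng.h/mL to 25000 ng.h/mL. The step of a 2.2-fold lower number from compound 2 to compound 3 (0.33 log units; beyond the scatter) is thus the estimate, not a measurement.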

Compound 3, area under the concentration-time curve: 11700 ng.h/mL
Compound 3: middle estimate off by 1.5-fold (0.17 log units), on the low side; measured number inside the range.
By their numbers in this assay, from the lowest: compound 1; then compounds 3 and 2 (each within the scatter of the next).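

In this assay, carbamoyl in place of (2-methoxyethoxy)methyl on this saturated chain carbon gives a 1.5-fold lower number from compound 2 to compound 3 (0.17 log units; within the scatter) and so leaves the number within the scatter, although carbamoyl has 3 heavy atoms against 6 and adds a hydrogen-bond donor. Set against compound 1, carbamoyl in place of pentyl gives a 5.0-fold higher number from compound 1 to compound 3 (0.70 log units; beyond the scatter) and thus separates compound 3 from compound 1 as well, so two different chain ends now stand clear of compound 1. Nothing on hand explains why compounds 2 and 3 cannot be told apart or why both stand clear of compound 1.

On these data alone, whether a carboxylic acid or an amine at this chain carbon would keep the number in the same region remains open. Also open, as far as these compounds go, is whether a longer chain of ethoxy units or a substituted amide in place of carbamoyl would move it beyond the scatter.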